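Nitro in place of 3-hydroxypropyl in the series

This account rests on a few compounds, and the source may have more. Where it says the series, first, only, none or still open, it means among the compounds named here.

Measured in a functional assay on DU-145 cells (Homo sapiens) for inhibition; a higher number here means a weaker inhibitor, a lower number a stronger inhibitor
- compound 1 `CCOc1ccc(Cl)cc1-c1cc(Nc2ccc(Cl)cc2)nc(N)n1` gives 70 nM
- compound 2 `CCOc1ccc(Cl)cc1-c1cc(Nc2ccc(CCCO)cc2)nc(N)n1` gives > 1000 nM

For compound 2, > 1000 nM is a limit and not a number. Compound 3 `CCOc1ccc(Cl)cc1-c1cc(Nc2ccc([N+](=O)[O-])cc2)nc(N)n1` carries nitro in place of 3-hydroxypropyl on an aromatic carbon. Going by the values given here, one measured step bears on this place: an at least 14-fold higher number from compound 1 to compound 2 (1.15 log units; beyond the scatter), large and beyond the scatter, with 3-hydroxypropyl replacing chloro. Nitro itself is unmeasured, so compound 1 at 70 nM is only a loose guide. With 3-hydroxypropyl gone, a sizeable move to a lower number is expected, estimated as an at least 6.6-fold lower number from compound 2 to compound 3 (0.82 log units; beyond the scatter). Compound 3 is expected at about 150 nM, with an estimated range of 40 nM to 800 nM.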

Compound 3, half-maximal inhibitory concentration: 350 nM
The estimate for compound 3 lay 2.3-fold (0.37 log units) below the measured number; measured number inside the range.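

In this assay nitro recovers part of what 3-hydroxypropyl gives up at this position (an at least 2.8-fold lower number from compound 2 to compound 3 (0.45 log units; beyond the scatter)), yet it does not reach chloro (a 5.0-fold higher number from compound 1 to compound 3 (0.70 log units; beyond the scatter)). The position therefore separates the three groups, and chloro gives the lowest number of them. The first step has only a lower bound, as compound 2 stands at a limit: the limit of > 1000 nM in this assay, at which 1 of the 3 values shown sits. Open, from the compounds shown here alone, is where an amine, a carboxylic acid or a small methyl group would fall relative to chloro and nitro at this position.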